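Swapping a Methyl for a Hydroxy on the Same Chain Carbon

The compounds below may be only part of what the source reports. "The series", "measured", "known", "first", "only" and "open" are said of these compounds alone.

Compound 1 `Cc1nc2ccc(C#CC(C)(C)O)cc2n1-c1ncnc(N)n1` and compound 2 `Cc1nc2ccc(C#CC(C)(C)CO)cc2n1-c1ncnc(N)n1` share one core and differ only on a short chain hanging from a triple bond. In an assay for binding affinity to serine/threonine-protein kinase PAK 1 (Homo sapiens), read by FRET and Z'-LYTE, with stated times of 10 min and 60 min (a higher number here means a weaker inhibitor, a lower number a stronger inhibitor), compound 1 gives 15300 nM. In this assay compound 2 gives no number but only a limit of the assay, > 4500 nM. The step that the limit leaves unreadable from compound 1 to compound 2 therefore cannot be sized because of the limit of > 4500 nM in this assay, at which 1 of the 2 values shown sits. Compound 3 `Cc1nc2ccc(C#CC(C)(O)CO)cc2n1-c1ncnc(N)n1` brings the change (hydroxy in place of methyl on a saturated chain carbon bound to two saturated chain carbons and a triple-bonded carbon). For the measured compounds named here, no measured step shows a hydroxy entering in place of a methyl at this place, and the single step at hand is unreadable, so no direction beyond the usual scatter can be foreseen in this assay. Compound 3 is expected to change by about a step that the limit leaves unreadable from compound 2 to compound 3. For compound 3 the estimate is 15000 nM, with a range from 4500 nM to 50000 nM, and a sizeable chance that only a limit is reported.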

Compound 3, inhibition constant: > 4500 nM
Compound 3 gave a limit, no number (the forecaster's own chance of this, stated with the estimate: 60%); the middle value lies beyond the limit too.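

Neither the step from compound 2 to compound 3 nor the step from compound 1 to compound 3 can be read, because the results stop at a limit: the limit of > 4500 nM in this assay, at which 2 of the 3 values shown sit.

Going by these compounds, what stays open is how a hydroxy in place of a methyl on this chain carbon changes the values of compound 2 and compound 3 in this assay as actual numbers.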